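The source may report more compounds than this note shows. Statements on the series, on what has been measured and on what is new or still open speak of the compounds shown alone.

Compound 1 `CC(C)COc1cccc(-c2ccc(C(=O)N(Cc3cccc(OCCCCCC(=O)O)c3)C(C)C)cc2)c1`: in an ADME assay on HEK293 cells (Homo sapiens) for cytotoxicity, read by CellTiter-Glo and resazurin assay, with a stated time of 72 h (on this read-out higher numbers stand for an effect only at larger amounts of compound and lower numbers for an effect already at smaller amounts), compound 1 gives > 26000 nM, which is a limit of the assay and not a number.
Compound 2 `CC(C)N(Cc1cccc(OCCCCCC(=O)O)c1)C(=O)c1ccc(-c2cccc(Oc3ccccc3)c2)cc1`: in this assay compound 2 gives > 18700 nM, also a limit.

Compound 1 therefore stands only at a limit (the limit of > 26000 nM in this assay, at which 1 of the 2 values shown sits). Among the compounds with values here, the one further value shown, for compound 2, is likewise a limit (the limit of > 18700 nM in this assay, at which 1 of the 2 values shown sits). The step that the two limits leave unreadable from compound 1 to compound 2 thus stays unreadable. Compound 3 `CC(C)N(Cc1cccc(OCCCCCC(=O)O)c1)C(=O)c1ccc(-c2ccc3cc[nH]c3c2)cc1` differs from compound 1 by 1H-indol-6-yl in place of 3-(isobutoxy)phenyl on an aromatic carbon. Within the data shown here, no measured step bears on this change, so in this assay nothing beyond another limit is expected, in no particular direction. Compound 3 is expected at 25000 nM, between 10000 nM and 60000 nM. This amounts to an estimated step of an at least 1.0-fold lower number from compound 1 to compound 3 (0.01 log units; that floor lies within the scatter).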

Compound 3, half-maximal effective concentration: > 26000 nM
Compound 3 was reported as a limit; the forecaster's own chance of this, stated with the estimate: 80%; middle value at least 1.0-fold (0.01 log units) away from the limit.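

In this assay, within the data shown here, compound 1 and compound 3 both stand at limits and not at numbers, so no step between them can be read. The concentration at which any compound shown would reach its half-maximal effect stays open.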